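Vinyl to Ethyl on the Sulfonyl Ring: What to Expect

The source may hold more compounds than are shown below. What is called first, only, known or untested is meant among the compounds shown, and "the series" means these compounds.

Compound 1 `O=S(=O)(Nc1ccc(-c2nc3ccccc3o2)cc1)c1ccccc1Cl` carries a 2-chlorophenyl on its sulfonyl sulfur. In an assay on isolated protein for inhibition of malate dehydrogenase, mitochondrial (Sus scrofa), with stated times of 45 min and 30 min (on this read-out higher numbers stand for weaker inhibition and lower numbers for stronger inhibition), compound 1 gives > 63000 nM, which is a limit of the assay rather than a number. Compound 2 `C=Cc1ccc(S(=O)(=O)Nc2ccc(-c3nc4ccccc4o3)cc2)cc1` carries a 4-vinylphenyl in the same place. In this assay compound 2 gives > 63000 nM, again a limit rather than a number. The step that the two limits leave unreadable from compound 1 to compound 2 is therefore unreadable. Where compound 2 stands is known only as the limit of > 63000 nM in this assay, at which 2 of the 2 values shown sit.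

Compound 3 `CCc1ccc(S(=O)(=O)Nc2ccc(-c3nc4ccccc4o3)cc2)cc1` differs from compound 2 by one change: ethyl in place of vinyl on an aromatic carbon. No measured step bears on this change; the only step shown, from one substituent on the sulfonyl sulfur to another, is itself unreadable. The expectation for compound 3 in this assay therefore rests on compound 2 alone, whose result > 63000 nM was only a limit. Compound 3 is expected to remain at the limit, giving about 100000 nM with a range from 30000 nM to 300000 nM. The expected step that the limit leaves unreadable from compound 2 to compound 3 is none beyond the scatter.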

Compound 3, half-maximal inhibitory concentration: > 63000 nM
Compound 3 was reported as a limit; the forecaster's own chance of this, stated with the estimate: 85%; the middle value lies beyond the limit too.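

No step can be read among compound 1, compound 2 and compound 3, as all three results are limits of the assay and not numbers: the limit of > 63000 nM in this assay, at which 3 of the 3 values shown sit. The compounds shown leave open whether swapping one group for another on the sulfonyl sulfur changes inhibition at all, and how large any such change would be.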